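Working notes: adding a fluoro group to compound 2

This account rests on a few compounds, and the source may have more. Where it says the series, first, only, none or still open, it means among the compounds named here.

Measured in an ADME assay on HOS cells (Homo sapiens) for cytotoxicity; a lower number here means a stronger inhibitor, a higher number a weaker inhibitor:
- compound 1 `O=C1c2c(ccc(O)c2O)CN1Cc1ccc(F)c(F)c1`: 9010 nM
- compound 2 `O=C1c2c(ccc(O)c2O)CN1Cc1ccc(F)c(Cl)c1`: 6870 nM

In this assay compound 2 gives 6870 nM, which lies within the scatter of compound 1 at 9010 nM, so the two cannot be ordered.

Compound 3 `O=C1c2c(ccc(O)c2O)CN1Cc1cc(Cl)c(F)cc1F` keeps the core of compound 2 and changes in one place: fluoro in place of hydrogen on an aromatic carbon. This is fluoro in place of hydrogen on an aromatic carbon, ortho to a large group, meta to a fluoro group and para to a chloro group.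

Going by the values given here, only one measured step is available: a 1.3-fold lower number from compound 1 to compound 2 (0.12 log units; within the scatter). It is chloro in place of fluoro on an aromatic carbon, not a replacement of hydrogen, so it bears on the new change only indirectly. Among the compounds with values here, the series holds no measured example of substitution at this place. No step beyond the scatter is therefore expected in this assay, and neither direction is favoured. The estimated change is a 1.1-fold lower number from compound 2 to compound 3 (0.02 log units; within the scatter). Compound 3 is expected at 6500 nM, with an estimated range from 2800 nM to 15000 nM.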

Compound 3, half-maximal inhibitory concentration: 8380 nM
Compound 3: the middle estimate sits 1.3-fold (0.11 log units) below what was measured; low and high end bracket the measured number.
By their numbers in this assay, from the lowest: compounds 2, 3 and 1 (each within the scatter of the next).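

In this assay, fluoro in place of hydrogen on the aromatic carbon ortho to a large group, meta to a fluoro group and para to a chloro group gives a 1.2-fold higher number from compound 2 to compound 3 (0.09 log units; within the scatter), so compound 3 cannot be ordered against compound 2. Going by these compounds alone, this is the only measured example of substitution at this place, and it shows that one added fluorine atom here produces no step that can be read in this assay. Nothing measured in the series speaks to the reason for this result.

The compounds shown leave open whether a different group at this same place, such as methoxy, trifluoromethyl, an amine or a carboxylic acid, would produce a step beyond the scatter, since fluoro is the only replacement of hydrogen here. They also leave open whether the same fluoro substitution would give a comparable result in a compound carrying fluoro rather than chloro on this ring, as the shared core with the substitution pattern of compound 1 would.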